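A Bromo Group Removed at the Cytotoxicity Limit

The source may hold more compounds than are shown below. What is called first, only, known or untested is meant among the compounds shown, and "the series" means these compounds.

Three measured compounds share one core. Compound 1 `COc1cc(OC)c(C(=O)/C=C/c2ccc(Cl)cc2)c(OC)c1` and compound 2 `COc1cc(OC)c(C(=O)/C=C/c2ccc(Br)cc2)c(OC)c1` differ only by bromo in place of chloro on an aromatic carbon, while compound 3 `COc1cc(O)c(C(=O)/C=C/c2ccccc2SC)c(OC)c1` differs more widely. In an ADME assay on cells (Fibroblast, Homo sapiens) for cytotoxicity, with a stated time of 48 h (a lower number here means a stronger inhibitor, a higher number a weaker inhibitor), compound 1 gives > 20000 nM, which is a limit of the assay rather than a number. Compound 2 likewise reaches only a limit, > 20000 nM. Compound 3 also stops at a limit, > 20000 nM. Hence (the limit of > 20000 nM in this assay, at which 3 of the 3 values shown sit), and a step that the two limits leave unreadable from compound 1 to compound 2 cannot be read. Compound 4 `COc1cc(OC)c(C(=O)/C=C/c2ccccc2)c(OC)c1` carries hydrogen in place of bromo on an aromatic carbon. Among the compounds with values here, no measured step has a readable size, so no shift beyond the scatter is expected. The expected step is a step that the limit leaves unreadable from compound 2 to compound 4. Compound 4 is therefore estimated at 30000 nM, between 15000 nM and 100000 nM, most likely again as a limit.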

Compound 4, half-maximal inhibitory concentration: > 20000 nM
Compound 4: a limit, no number; the forecaster's own chance of this, stated with the estimate: 85%; the middle value is on the limit's open side.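

No step can be read among compound 1, compound 2 and compound 4, since each stands only at a limit of this assay: the limit of > 20000 nM in this assay, at which 4 of the 4 values shown sit.

What the compounds shown leave open is whether any change on the shared core would bring a readable value.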